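Fluoro for methyl on the furan-linked phenyl ring

The compounds below may be only part of what the source reports. "The series", "measured", "known", "first", "only" and "open" are said of these compounds alone.

Compound 1 `C=C1CCC(c2csc(/C=C(\C)C(N)=O)c2)CC1` gives 18000 nM in a functional assay on HO8910 cells (Homo sapiens) for cytotoxicity, read by CCK-8 assay, with a stated time of 24 h; on this read-out higher numbers stand for weaker inhibition and lower numbers for stronger inhibition.
Compound 2 `C/C(=C\c1cc(-c2ccccc2)co1)C(N)=O` gives 42400 nM in this assay.
Compound 3 `C/C(=C\c1cc(-c2ccc(C)cc2)co1)C(N)=O` gives 24200 nM in this assay.

Among these three numbers compound 3 stands second highest. Its nearest neighbour is compound 1 and its furthest is compound 2, and both gaps are within the scatter, so no order among the three is claimed. Compound 4 `C/C(=C\c1cc(-c2ccc(F)cc2)co1)C(N)=O` has not yet been measured. It differs from compound 3 by fluoro in place of methyl on an aromatic carbon. Going by the values given here, the only measured step at this position is a 1.8-fold lower number from compound 2 to compound 3 (0.24 log units; within the scatter), in which methyl entered in place of hydrogen and the number moved within the scatter only. Among the compounds with values here, no measured step shows how fluoro at this position behaves, and the single step that bears on it was small, so the expected step in this assay is none beyond the scatter, with a wide range to reflect the thin evidence. Compound 4 is therefore estimated at 30000 nM, expected to lie between 12000 nM and 75000 nM. This estimate means a step of a 1.2-fold higher number from compound 3 to compound 4 (0.09 log units; within the scatter), expected to stay within the scatter.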

Compound 4, half-maximal inhibitory concentration: > 50000 nM
Compound 4: only a limit was reported (the forecaster's own chance of this, stated with the estimate: 20%); middle value at least 1.6-fold (0.22 log units) away from the limit.
By their numbers in this assay, from the lowest: compounds 1, 3 and 2 (each within the scatter of the next, the first and the last beyond it). At a limit, above all of these: compound 4.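

Compound 4 reads > 50000 nM in this assay, and this reading is a limit of the assay, not a number. Going by these compounds alone, on the aromatic carbon para to a large group, fluoro in place of methyl gives an at least 2.0-fold higher number from compound 3 to compound 4 (0.31 log units; beyond the scatter), the first step at this position to lie beyond the scatter, so the group here can matter in a way the earlier hydrogen-to-methyl step did not show. Fluoro in place of hydrogen gives an at least 1.1-fold higher number from compound 2 to compound 4 (0.07 log units; that floor lies within the scatter), and with that floor within the scatter, compound 4 cannot yet be told apart from compound 2.

How far the true value of compound 4 lies past its limit stays open: the limit of > 50000 nM in this assay, at which 1 of the 4 values shown sits. The compounds shown also leave open how a chloro, methoxy or amine group at this position would read in this assay.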